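The source may hold more compounds than are shown below. What is called first, only, known or untested is meant among the compounds shown, and "the series" means these compounds.

Three compounds from one small series were tested in an assay on isolated protein for inhibition of thyroid hormone receptor beta (Homo sapiens), read by fluorescence polarization; a lower number here means a stronger inhibitor, a higher number a weaker inhibitor. Compound 1 `CN(Cc1cccc(F)c1)C(=O)CCCNC(=O)c1ccc(S(C)(=O)=O)c([N+](=O)[O-])c1` carries a longer saturated chain between its two amide groups, and in this assay compound 1 gives only a limit of the assay, > 60000 nM. Compound 2 `CN(Cc1cccc(F)c1)C(=O)CN(C)C(=O)c1ccc(S(C)(=O)=O)c([N+](=O)[O-])c1` shares the end groups of compound 1, but the difference between the two cores is not broken down here. In this assay compound 2 likewise gives a limit, > 60000 nM. Compound 3 `CC1CCN(C(=O)CCCNC(=O)c2ccc(S(C)(=O)=O)c([N+](=O)[O-])c2)CC1` is compound 1 with one change, (4-methylpiperidin-1-yl in place of (3-fluorobenzyl)(methyl)amino on a carbonyl carbon). In this assay compound 3 also gives a limit, > 60000 nM. The measured step that the two limits leave unreadable from compound 1 to compound 3 therefore cannot be sized, because of the limit of > 60000 nM in this assay, at which 3 of the 3 values shown sit. Compound 4 `CC1CCN(C(=O)CN(C)C(=O)c2ccc(S(C)(=O)=O)c([N+](=O)[O-])c2)CC1` has not yet been measured; it is compound 2 with the same change, (4-methylpiperidin-1-yl in place of (3-fluorobenzyl)(methyl)amino on a carbonyl carbon), at the same place. For compound 4 the step that the limit leaves unreadable from compound 2 to compound 4 is expected to be unreadable in the same way, because of the limit of > 60000 nM in this assay, at which 3 of the 3 values shown sit. In this assay compound 4 is expected to give about 100000 nM, most likely again only a limit, within a range of 30000 nM to 400000 nM.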

Compound 4, half-maximal inhibitory concentration: > 60000 nM
Compound 4 was reported as a limit; the forecaster's own chance of this, stated with the estimate: 85%; the middle value lies beyond the limit too.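

Compound 2 and compound 4 both appear in this assay only as limits, so the change from compound 2 to compound 4 gives no step that can be read: the limit of > 60000 nM in this assay, at which 4 of the 4 values shown sit.

The compounds shown leave open how the 4-methylpiperidin-1-yl and (3-fluorobenzyl)(methyl)amino groups compare, how the two cores compare, and what structure would give a measurable value.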